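The compounds below may be only part of what the source reports. "The series", "measured", "known", "first", "only" and "open" are said of these compounds alone.

Measured in an assay on cells for inhibition of Palmitoleoyl-protein carboxylesterase NOTUM variant C330S (Homo sapiens), read by fluorescence, with a stated time of 40 min; a lower number here means a stronger inhibitor, a higher number a weaker inhibitor: compound 1 `O=C(O)C1CCN(c2ccccc2)C1` gives 48000 nM; compound 2 `Cc1cc(C(=O)O)c(C)n1-c1ccccc1F` gives 3300 nM; compound 3 `Cc1ccccc1-n1c(C)cc(C(=O)O)c1C` gives 2200 nM.

Compound 3 carries the lowest of the three numbers, but its gap to compound 2 is within the scatter, so the two cannot be ordered; compound 1 sits clearly higher than both. Compound 4 `Cc1cc(C(=O)O)c(C)n1-c1ccccc1Cl` differs from compound 3 by chloro in place of methyl on an aromatic carbon. Within the data shown here, the one measured step at this same aromatic carbon, a 1.5-fold lower number from compound 2 to compound 3 (0.18 log units; within the scatter), stayed within the scatter, so a swap of one small group for another there has so far moved the number little. For compound 4 the expected step is a 1.1-fold higher number from compound 3 to compound 4 (0.06 log units; within the scatter), within the scatter. The estimate for compound 4 in this assay is 2500 nM, range 1200 nM to 5500 nM.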

Compound 4, half-maximal inhibitory concentration: 2300 nM
Compound 4: the middle estimate sits 1.1-fold (0.04 log units) above what was measured; the measured number falls inside the stated range.
By their numbers in this assay, from the lowest: compounds 3, 4 and 2 (each within the scatter of the next); then compound 1.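

In this assay, chloro now joins fluoro and methyl at this aromatic carbon, ortho to a large group: a 1.0-fold higher number from compound 3 to compound 4 (0.02 log units; within the scatter) and a 1.4-fold lower number from compound 2 to compound 4 (0.16 log units; within the scatter) both lie within the scatter. Among these compounds, the three groups therefore cannot be ordered, whereas the earlier compounds gave only one comparison at this place. No measurement shown accounts for this flat reading.

Open, on these data alone, is whether methoxy, an amine or a longer chain at this carbon would move the number beyond the scatter. Also open, as far as these compounds go, is how the number responds to a plain hydrogen there.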